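Replacing Chloro with a Methylpyrazole Ring on Compound 1

The source may hold more compounds than are shown below. What is called first, only, known or untested is meant among the compounds shown, and "the series" means these compounds.

Compound 1 `COc1cc(-c2ccnc3cc(-c4ccc(Cl)cc4)nn23)cc(OC)c1OC` stands at the upper end of the three measured numbers in a functional assay on HCT-116 cells (Homo sapiens) for inhibition, read by CCK-8 assay, with a stated time of 48 h (on this read-out higher numbers stand for weaker inhibition and lower numbers for stronger inhibition), giving 3340 nM. Compound 3 `COc1ccc(-c2cc3nccc(-c4cc(OC)c(OC)c(OC)c4)n3n2)cc1F` gives 2840 nM; the step of a 1.2-fold lower number from compound 1 to compound 3 (0.07 log units; within the scatter) stays within the scatter. Compound 2 `COc1cc(-c2ccnc3cc(-c4ccc5ccn(C)c5c4)nn23)cc(OC)c1OC` gives 1040 nM, and the step of a 3.2-fold lower number from compound 1 to compound 2 (0.51 log units; beyond the scatter) is modest but beyond the scatter. Compound 4 `COc1cc(-c2ccnc3cc(-c4ccc(-c5cnn(C)c5)cc4)nn23)cc(OC)c1OC` differs from compound 1 in one place: 1-methyl-1H-pyrazol-4-yl in place of chloro on an aromatic carbon. Within the data shown here, the step that bears on this is the one to compound 2, where 1-methyl-1H-indol-6-yl in place of 4-chlorophenyl lowered the number, whereas 3-fluoro-4-methoxyphenyl changed little. A modest lowering is therefore expected, a 2.2-fold lower number from compound 1 to compound 4 (0.35 log units; beyond the scatter). Compound 4 is estimated at 1500 nM, within 600 nM to 4000 nM.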

Compound 4, half-maximal inhibitory concentration: 2110 nM
Compound 4: the middle estimate sits 1.4-fold (0.15 log units) below what was measured; measured number inside the range.
By their numbers in this assay, from the lowest: compound 2; then compounds 4, 3 and 1 (each within the scatter of the next).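

With a 1.6-fold lower number from compound 1 to compound 4 (0.20 log units; within the scatter) in this assay, the step stays within the scatter, so on this aromatic carbon, para to a large group, a whole 1-methyl-1H-pyrazol-4-yl ring can take the place of chloro without a clear change in the number. Unlike the earlier steps, which exchanged the entire 4-chlorophenyl group, this one keeps the phenyl ring and changes only what it carries. No measurement shown here accounts for this result. As far as these compounds go, whether an amine, a carboxylic acid or a morpholine ring at this same place would move the number remains open.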